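A few compounds are considered here, and "the series" means these few. Any claim that something is new, unique, unknown or untested is made for them only; others in the source may bear on it.

Measured so far in a functional assay, with a stated time of 25 min (on this read-out lower numbers stand for stronger inhibition and higher numbers for weaker inhibition), are three compounds:
compound 1 `COc1cc(/C=C/C(=O)NCCC(=O)Nc2ccccc2)ccc1O` with 95600 nM
compound 2 `COc1cccc(N2CCN(C(=O)/C=C/c3ccc(O)c(OC)c3)CC2)c1` with 62000 nM
compound 3 `COc1cccc(NC(=O)CCNC(=O)/C=C/c2ccc(O)c(OC)c2)c1` with 89100 nM

Compound 3 stands within the scatter of both compound 1 and compound 2, so these numbers set no order among the three compounds. The next compound, compound 4 `COc1cc(/C=C/C(=O)NCCC(=O)Nc2ccc(Cl)cc2)ccc1O`, is reached from compound 3 by a single change, in which 4-chlorophenyl comes in place of 3-methoxyphenyl on an amide-type nitrogen, counted as 4-chlorophenyl in place of 3-methoxyphenyl on an amide-type nitrogen with the rest of the structure kept.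

For the measured compounds named here, only one measured step bears on this aromatic group. It is a 1.1-fold lower number from compound 1 to compound 3 (0.03 log units; within the scatter) for methoxy in place of hydrogen on an aromatic carbon, and it lies within the scatter. Going by the values given here, no measured compound carries the 4-chlorophenyl group, so the data hold no direct step for it. A change on this group is therefore expected to move the number only a little, and no step beyond the scatter is expected in this assay at this stage. The expected change is a 1.3-fold lower number from compound 3 to compound 4 (0.10 log units; within the scatter) and would stay within the scatter. For compound 4 the estimated value is 70000 nM with an expected range from 30000 nM to 150000 nM in this read-out.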

Compound 4, half-maximal inhibitory concentration: 84200 nM
The estimate for compound 4 lay 1.2-fold (0.08 log units) below the measured number, and the stated range covers the measured number.
By their numbers in this assay, from the lowest: compounds 2, 4, 3 and 1 (each within the scatter of the next).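

In this assay, 4-chlorophenyl in place of 3-methoxyphenyl on the amide-type nitrogen gives a 1.1-fold lower number from compound 3 to compound 4 (0.02 log units; within the scatter), so exchanging one substituted aromatic group for the other leaves no readable difference at this position. Chloro in place of hydrogen on an aromatic carbon gives a 1.1-fold lower number from compound 1 to compound 4 (0.06 log units; within the scatter), which adds a second substituent to the earlier methoxy step, and neither step leaves the scatter. Across compound 1, compound 3 and compound 4, this position has therefore tolerated hydrogen, methoxy and chloro without a measurable difference, although nothing available explains this result.

As far as these compounds go, it remains open whether an amine or a carboxylic acid on this aromatic ring, or a longer chain in the shared core, would give a step beyond the scatter. From the compounds shown here alone, it also remains open whether the read-out depends on the hydroxy and methoxy groups that all four compounds share, since changes elsewhere may matter more than those at this position.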